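Piperazine for Diethylamine on a Longer Side Chain

The compounds below may be only part of what the source reports. "The series", "measured", "known", "first", "only" and "open" are said of these compounds alone.

Measured so far:
compound 1 `CCN(CC)CCn1c(N)c(-c2nc3ccccc3[nH]2)c2nc(C#N)c(C#N)nc21` gives 8950 nM.
compound 2 `CN1CCN(CCn2c(N)c(-c3nc4ccccc4[nH]3)c3nc(C#N)c(C#N)nc32)CC1` reaches only a limit of the assay, > 50000 nM.
compound 3 `CCN(CC)CCCn1c(N)c(-c2nc3ccccc3[nH]2)c2nc(C#N)c(C#N)nc21` gives 1870 nM.

All three share one core and differ only in the side chain that hangs from an aromatic nitrogen. In a functional assay on Raji cells (Homo sapiens) for antiproliferative activity, read by MTT assay, with a stated time of 48 h (on this read-out lower numbers stand for stronger inhibition and higher numbers for weaker inhibition), compound 1 gives 8950 nM. In this assay compound 2 gives no number but a limit, > 50000 nM. In this assay compound 3 gives 1870 nM.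

The change 4-methylpiperazin-1-yl in place of diethylamino on a saturated chain carbon, two bonds along the chain from an aromatic nitrogen made an at least 5.5-fold higher number from compound 1 to compound 2 (0.74 log units; beyond the scatter). The change (diethylamino)methyl in place of diethylamino on a saturated chain carbon, two bonds along the chain from an aromatic nitrogen made a 4.8-fold lower number from compound 1 to compound 3 (0.68 log units; beyond the scatter); this is also how the cores of compound 3 and compound 1 differ. Between the two, an at least 26-fold lower number from compound 2 to compound 3 (1.42 log units; beyond the scatter). One of the three values sits at the limit of > 50000 nM in this assay, at which 1 of the 3 values shown sits.

Compound 4 `CN1CCN(CCCn2c(N)c(-c3nc4ccccc4[nH]3)c3nc(C#N)c(C#N)nc32)CC1` has not yet been measured. It differs from compound 3 by 4-methylpiperazin-1-yl in place of diethylamino on a saturated chain carbon, three bonds along the chain from an aromatic nitrogen. This is the same kind of change as from compound 1 to compound 2, but the place is not the same: there it was two bonds along the chain from an aromatic nitrogen, here it is three.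

For compound 4 a step of about an 8.0-fold higher number from compound 3 to compound 4 (0.90 log units; beyond the scatter) is expected. Going by these compounds, that expectation rests on the earlier step of an at least 5.5-fold higher number from compound 1 to compound 2 (0.74 log units; beyond the scatter), which was already at the limit, so its full size is unknown. Compound 4 is estimated at 15000 nM in this assay, with a likely range from 6000 nM to 50000 nM.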

Compound 4, half-maximal inhibitory concentration: 2620 nM
Estimate against measurement, compound 4: 5.7-fold (0.76 log units) above, outside the stated range (below it).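

In this assay, putting 4-methylpiperazin-1-yl in place of diethylamino on the 3-(diethylamino)propyl side chain gives a 1.4-fold higher number from compound 3 to compound 4 (0.15 log units; within the scatter), so on this core the swap has no effect that can be told from the scatter, and it does not repeat what it did on the 2-(diethylamino)ethyl side chain: the same change on two cores in this assay, an at least 5.5-fold higher number (0.74 log units; beyond the scatter) from compound 1 to compound 2 and a 1.4-fold higher number (0.15 log units; within the scatter) from compound 3 to compound 4, at least 3.9-fold (0.60 log units) apart, beyond the scatter of two such steps

Going by these compounds, compound 2 gives only a limit, > 50000 nM, so the full size of the earlier step is unknown.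

Within the piperazine pair, the longer chain gives an at least 19-fold lower number from compound 2 to compound 4 (1.28 log units; beyond the scatter), and the step that changes both the amine and the chain gives a 3.4-fold lower number from compound 1 to compound 4 (0.53 log units; beyond the scatter), but these few pairs show only that the swap did not carry over unchanged from one core to the other, not why it did not, nor what it would do on any other core.

The compounds shown leave open whether the swap stays this small on a still longer chain. They also leave open whether another ring amine, such as morpholine or piperidine, on the propyl chain would give a value close to those of compound 3 and compound 4.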